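A few compounds are considered here, and "the series" means these few. Any claim that something is new, unique, unknown or untested is made for them only; others in the source may bear on it.

Measured compounds:
compound 1, `CC(=O)Nc1ccc(CNC2CCN(CCCc3c[nH]c4ccc(-n5cnnc5)cc34)CC2)cc1`, 45 nM
compound 2, `CN(Cc1ccco1)C1CCN(CCCc2c[nH]c3ccc(-n4cnnc4)cc23)CC1`, 89 nM
compound 3, `CN(C1CCN(CCCc2c[nH]c3ccc(-n4cnnc4)cc23)CC1)S(=O)(=O)c1ccccc1`, 10 nM

In an assay on CHO cells for displacement of a labelled ligand from 5-hydroxytryptamine receptor 1B (Homo sapiens) (a higher number here means a weaker inhibitor, a lower number a stronger inhibitor), compound 3 gives the lowest number of the three, with compound 1 the nearest and compound 2 the furthest. Within the data shown here, the one single-point step among the measured compounds is an 8.9-fold lower number from compound 2 to compound 3 (0.95 log units; beyond the scatter), where a phenylsulfonyl group in place of a (furan-2-yl)methyl group on the amine nitrogen gave the lower number.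

The next compound, compound 4, `CC(=O)Nc1ccc(CN(C)C2CCN(CCCc3c[nH]c4ccc(-n5cnnc5)cc34)CC2)cc1`, is not yet measured. Compared with compound 3 it has 4-acetamidobenzyl in place of phenylsulfonyl on an amine nitrogen. This step runs in the opposite sense to the measured one: an aromatic ring attached through a methylene again replaces the phenylsulfonyl group on the same amine nitrogen. Compound 1, which carries the 4-acetamidobenzyl group on an amine nitrogen without the methyl, gives a number well above that of compound 3. On that basis the number for compound 4 is expected to rise beyond the scatter, by a step of about a 4.0-fold higher number from compound 3 to compound 4 (0.60 log units; beyond the scatter), though the 4-acetamidobenzyl group is not the (furan-2-yl)methyl group and the size is uncertain. Compound 4 is therefore estimated at 40 nM, within a range of 15 nM to 120 nM.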

Compound 4, half-maximal inhibitory concentration: 100 nM
The estimate for compound 4 lay 2.5-fold (0.40 log units) below the measured number; measured number inside the range.
By their numbers in this assay, from the lowest: compound 3; then compounds 1, 2 and 4 (each within the scatter of the next, the first and the last beyond it).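

In this assay, a second group attached through a methylene now stands against phenylsulfonyl on this amine nitrogen, with a 10-fold higher number from compound 3 to compound 4 (1.00 log units; beyond the scatter) for the change to 4-acetamidobenzyl, so the low number of compound 3 is not matched by either of these groups. The aromatic ring carried on the saturated chain carbon bound to the amine nitrogen matters little between these two groups, as a 1.1-fold higher number from compound 2 to compound 4 (0.05 log units; within the scatter) for 4-acetamidophenyl in place of furan-2-yl stays within the scatter. The nitrogen's own methyl also counts, since a 2.2-fold higher number from compound 1 to compound 4 (0.35 log units; beyond the scatter) shows that methyl in place of hydrogen gives a higher number when the 4-acetamidobenzyl group is present.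

From the compounds shown here alone, it remains open whether the same methyl step holds with phenylsulfonyl on the nitrogen, and whether an acetyl or benzoyl group there, or a 4-methoxyphenylsulfonyl group, would keep a number as low as that of compound 3. Nothing available here offers an explanation for any of these steps.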